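Removing the bromoacrylamide from the aniline nitrogen

A few compounds are considered here, and "the series" means these few. Any claim that something is new, unique, unknown or untested is made for them only; others in the source may bear on it.

Measured so far:
compound 1, `Nc1ccc(/C=C2\SC(=O)N(Cc3ccc(C(F)(F)F)cc3)C2=O)cc1`: 96000 nM
compound 2, `C=C(Br)C(=O)Nc1ccc(/C=C2\SC(=O)N(Cc3ccc(C(F)(F)F)cc3)C2=O)cc1`: 13000 nM
compound 3, `C=C(Br)C(=O)Nc1cccc(/C=C2\SC(=O)N(Cc3ccc(C)cc3)C2=O)c1`: 1200 nM

All numbers come from a functional assay on HeLa cells (Homo sapiens) for cytotoxicity, read by cell counting, with a stated time of 4 days; a lower number here means a stronger inhibitor, a higher number a weaker inhibitor. Compound 1 differs from compound 2 by hydrogen in place of (1-bromoethenyl)carbonyl on a nitrogen on an aromatic ring; that change gave a 7.4-fold higher number from compound 2 to compound 1 (0.87 log units; beyond the scatter). Compound 3 gives the lowest number of the three, its steps to compound 2 and compound 1 both lying beyond the scatter. How the core of compound 3 differs from the core of compound 2 is not broken down here.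

Compound 4, `Cc1ccc(CN2C(=O)S/C(=C\c3cccc(N)c3)C2=O)cc1`, stands to compound 3 as compound 1 stands to compound 2; the change is hydrogen in place of (1-bromoethenyl)carbonyl on a nitrogen on an aromatic ring, the same change at the same place. The expected step is a 7.5-fold higher number from compound 3 to compound 4 (0.88 log units; beyond the scatter), resting on the earlier 7.4-fold higher number from compound 2 to compound 1 (0.87 log units; beyond the scatter), carried over to the core of compound 3. In this assay compound 4 is estimated at 9000 nM, expected to fall between 3000 nM and 30000 nM.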

Compound 4, half-maximal inhibitory concentration: 98000 nM
Compound 4: middle estimate off by 11-fold (1.04 log units), on the low side, and the stated range ends below it.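

Removing the (1-bromoethenyl)carbonyl group from the nitrogen raises the number on both cores in this assay, and on the core of compound 3 the result is an 82-fold higher number from compound 3 to compound 4 (1.91 log units; beyond the scatter). Only the direction of the change carries over between these two cores, not its size: the same change on two cores in this assay, a 7.4-fold higher number (0.87 log units; beyond the scatter) from compound 2 to compound 1 and an 82-fold higher number (1.91 log units; beyond the scatter) from compound 3 to compound 4, 11-fold (1.04 log units) apart, beyond the scatter of two such steps. Two pairs do not show which difference between the cores goes with this gap, nor whether the direction would hold on a further core.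

Open, from the compounds shown here alone, is how an acetyl or an unsubstituted acryloyl group on the same nitrogen would compare with (1-bromoethenyl)carbonyl and with hydrogen. Also open, going by these compounds, is whether trifluoromethyl in place of methyl, with the rest of the core of compound 3 kept, would alter the step.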